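The source may report more compounds than this note shows. Statements on the series, on what has been measured and on what is new or still open speak of the compounds shown alone.

Measured compounds:
compound 1 `COc1ccc(-c2cnc3nc(N)nc(N4CCN(C(=O)COc5ccccc5)CC4)c3n2)cc1OC`: 4 nM
compound 2 `CCOc1nc(N)nc2ncc(-c3ccc(C#N)cc3)nc12`: > 10000 nM

Among the measured compounds shown here, in a functional assay on cells (T-cell, Homo sapiens) for inhibition (a lower number here means a stronger inhibitor, a higher number a weaker inhibitor), compound 1 gives 4 nM, and this is the only number among the two measured compounds. For compound 2 the assay reports only (the limit of > 10000 nM in this assay, at which 1 of the 2 values shown sits), a limit and not a number. For the measured compounds named here, compound 1 therefore stands alone with a measured value, and there is no measured pair differing in a single place from which the size of any step could be read.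

Compound 3 `COc1ccc(-c2cnc3nc(N)nc(N4CCN(C(=O)Nc5ccccc5)CC4)c3n2)cc1OC` differs from compound 1 in one place: anilino in place of phenoxymethyl on a carbonyl carbon. The aromatic ring is retained, a hydrogen-bond donor enters where a hydrogen-bond acceptor leaves, and the count of heavy atoms changes by one. Going by the values given here, with no measured step to rest on, the change from compound 1 to compound 3 is expected to be small, a 1.8-fold higher number from compound 1 to compound 3 (0.24 log units; within the scatter), likely within the scatter or at most a modest loss. Compound 3 is estimated at 7 nM, within a range from 2 nM to 30 nM.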

Compound 3, half-maximal inhibitory concentration: 3.4 nM
For compound 3 the middle estimate is 2.1-fold (0.31 log units) above the measured one; low and high end bracket the measured number.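

Among the compounds shown here, the first step that can be read at this place is a 1.2-fold lower number from compound 1 to compound 3 (0.07 log units; within the scatter) in this assay, so anilino and phenoxymethyl on a carbonyl carbon cannot be told apart by this read-out. For this one change, a hydrogen-bond donor can enter where a hydrogen-bond acceptor leaves, with the aromatic ring retained, and no shift beyond the scatter follows. Nothing measured here gives a cause for this step.

The compounds shown leave open whether the aromatic ring is needed at all on this carbonyl carbon, a question that a methyl or cyclohexyl group there would address. They also leave open whether the amide hydrogen of compound 3 plays any part, which a methylated anilino group would test.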